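The source may hold more compounds than are shown below. What is called first, only, known or untested is meant among the compounds shown, and "the series" means these compounds.

Compound 1 `O=C(CCCCC(S)CCS)Nc1ccc(Cl)cc1`: 1.06%
Compound 2 `Cc1cccc(NC(=O)CCCCC(S)CCS)c1`: 10.1%

In a functional assay on Bel-7402 cells (Homo sapiens) for inhibition, read by MTT assay, with a stated time of 24 h, tested at 0.1 ug/mL (on this read-out higher numbers stand for more inhibition of growth at the one concentration tested and lower numbers for less inhibition of growth), compound 1 gives 1.06% and compound 2 gives 10.1%. Going by the values given here, these two numbers lie within the usual scatter of each other, so they cannot be ranked, and compound 1 stands level with the only other measured compound. Compound 3 `O=C(CCCCC(S)CCS)Nc1ccc([N+](=O)[O-])cc1` has not yet been measured. It keeps the core of compound 1 and changes one group: nitro in place of chloro on an aromatic carbon. In short, this is nitro in place of chloro on an aromatic carbon, para to a large group. Among the compounds with values here, no measured pair differs in one place only, so the data offer no direct guide to this change. In this assay, no step beyond the scatter is expected, in either direction. For compound 3 the estimated value is 7%, with an expected range from 0% to 20%. This estimate amounts to an expected a number 5.9 percentage points higher from compound 1 to compound 3 (within the scatter).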

Compound 3, percent growth inhibition at one concentration: 1.88%
The estimate for compound 3 lay 5.1 percentage points above the measured number; measured number inside the range.
By their numbers in this assay, from the lowest: compounds 1, 3 and 2 (each within the scatter of the next).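

In this assay, going by these compounds alone, nitro in place of chloro on an aromatic carbon, para to a large group, gives a number 0.8 percentage points higher from compound 1 to compound 3 (within the scatter), and this is the first comparison in the set between compounds that differ in one place only. At this position, then, replacing a single chlorine atom with a group of 3 heavy atoms that brings 2 hydrogen-bond acceptors leaves no difference that can be read at the one concentration tested. No measurement shown here offers an explanation for this result.

On these data alone, whether any group at this position can move the number beyond the scatter remains open, and an amine or a carboxylic acid there would test this further. The single concentration also leaves open whether compound 1 and compound 3 would still read alike at other concentrations.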